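Swapping the aryl ketone on a shared benzothiazole-free core

The source may report more compounds than this note shows. Statements on the series, on what has been measured and on what is new or still open speak of the compounds shown alone.

The set begins with two measured compounds. Among the compounds with values here, compound 1 `COc1ccc2nc(-c3ccc(N/C=C\C(=O)c4ccc(OC)c(O)c4)c(C)c3)sc2c1` and compound 2 `COc1cc(OC)c2sc(-c3ccc(N/C=C\C(=O)c4cc(OC)c(OC)c(OC)c4)cc3)nc2c1` share the same enaminone linker but differ in both the core and the aryl ketone, so no single step connects them. In a functional assay on MIA PaCa-2 cells (Homo sapiens) for antiproliferative activity, read by sulforhodamine B assay, with a stated time of 48 h (on this read-out higher numbers stand for weaker inhibition and lower numbers for stronger inhibition), compound 1 gives 17000 nM, and in this assay compound 2 gives 26800 nM; the two numbers lie within the usual scatter of each other, so neither can be set apart from the other on this read-out.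

Compound 3 `COc1cc(OC)c2sc(-c3ccc(N/C=C\C(=O)c4ccc(OC)c(O)c4)cc3)nc2c1` keeps the core of compound 2 and changes only the aryl ketone: 3-hydroxy-4-methoxyphenyl in place of 3,4,5-trimethoxyphenyl on a carbonyl carbon. The same aryl ketone is present in compound 1, whose value sits close to that of compound 2, which gives no sign that this part of the molecule moves the read-out much. For compound 3 the expected step is therefore a 1.3-fold lower number from compound 2 to compound 3 (0.13 log units; within the scatter), in no particular direction and not beyond the scatter. The estimate for compound 3 in this assay is 20000 nM, with a range from 8000 nM to 50000 nM.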

Compound 3, half-maximal inhibitory concentration: 11600 nM
The estimate for compound 3 lay 1.7-fold (0.24 log units) above the measured number, within the range that was stated.
By their numbers in this assay, from the lowest: compounds 3, 1 and 2 (each within the scatter of the next, the first and the last beyond it).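

Within the data shown here, with the core held fixed, 3-hydroxy-4-methoxyphenyl in place of 3,4,5-trimethoxyphenyl on a carbonyl carbon gives a 2.3-fold lower number from compound 2 to compound 3 (0.36 log units; beyond the scatter) in this assay and so provides the first direct reading of this position. The aryl group on the carbonyl carbon can therefore shift the read-out on this core, although the step is modest and all of the values remain in the high range printed for this small set. The change replaces 12 heavy atoms with 9 and brings in a hydrogen-bond donor, but this one step cannot separate those differences, and no measurement shown here explains the result.

It remains open whether the same exchange would give a step of similar size and direction on the core of compound 1, since the compounds shown offer a single-change comparison on the core of compound 2 only. As far as these compounds go, it is also open how the read-out would respond if an amine or a carboxylic acid stood on this aryl ring in place of the hydroxyl group of compound 3.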